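Enaminone series: chloro for nitro, measurements still at limit

The compounds below may be only part of what the source reports. "The series", "measured", "known", "first", "only" and "open" are said of these compounds alone.

Measured so far, in a functional assay on cells (Homo sapiens) for inhibition; on this read-out higher numbers stand for weaker inhibition and lower numbers for stronger inhibition:
compound 1 `CN(O)/C=C\C(=O)c1ccc([N+](=O)[O-])cc1` gives > 10000 nM.
compound 2 `CN(O)/C=C\C(=O)c1ccc(Cl)cc1` gives > 10000 nM.
compound 3 `CC(=O)ON(/C=C\C(=O)c1ccc([N+](=O)[O-])cc1)Cc1ccccc1` gives > 10000 nM.

Each of these three values is a limit of this assay, not a number. The change from compound 1 to compound 2 is chloro in place of nitro on an aromatic carbon, and the step it made is a step that the two limits leave unreadable from compound 1 to compound 2; the reason it cannot be read is the limit of > 10000 nM in this assay, at which 3 of the 3 values shown sit, at which both compounds sit. Compound 3 carries a different core from compound 1; the difference between the two cores is not broken down here, and compound 3 likewise stands only at a limit.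

The compound not yet measured is compound 4 `CC(=O)ON(/C=C\C(=O)c1ccc(Cl)cc1)Cc1ccccc1`. Its difference from compound 3 is chloro in place of nitro on an aromatic carbon. Going by the values given here, this is the same kind of change as the one from compound 1 to compound 2; around the place, the substituent is para to a large group in compound 3, whereas in compound 1 it is para to a group of 7 heavy atoms.

Among the compounds with values here, since the measured change from compound 1 to compound 2 left both compounds at a limit, and compound 3 also sits at a limit, the step from compound 3 to compound 4 in this assay is expected to be a step that the limit leaves unreadable from compound 3 to compound 4, which means only that no change readable from a limit is expected. Compound 4 is thus estimated at 20000 nM, with a range of 8000 nM to 60000 nM, and most likely this assay will again report only a limit.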

Compound 4, half-maximal inhibitory concentration: > 10000 nM
Compound 4 was reported as a limit; the forecaster's own chance of this, stated with the estimate: 85%; the middle value does not contradict the limit.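

In this assay compound 4 gives > 10000 nM, which is a limit and not a number. The change of nitro to chloro from compound 3 to compound 4 therefore yields no readable step, just as from compound 1 to compound 2: the limit of > 10000 nM in this assay, at which 4 of the 4 values shown sit.

The compounds shown leave open whether chloro and nitro differ at all in inhibition, and whether the shared enaminone series reaches a measurable value in this read-out.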